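The source may report more compounds than this note shows. Statements on the series, on what has been measured and on what is new or still open speak of the compounds shown alone.

Compound 1 `Nc1ccccc1NC(=O)/C=C/c1ccc(Cn2cnc3c(Nc4cccc(Cl)c4)nc(Cl)nc32)cc1` gives 7.11% in a functional assay on NCI-H460 cells (Homo sapiens) for antiproliferative activity, read by CCK-8 assay, with a stated time of 72 h, tested at 2 uM; a higher number here means a stronger effect of the compound at the concentration tested, a lower number a weaker effect.
Compound 2 `Nc1ccccc1NC(=O)c1ccc(Cn2cnc3c(NCc4ccccc4)nc(Cl)nc32)cc1` gives 44.7% in this assay.
Compound 3 `Nc1ccccc1NC(=O)/C=C/c1ccc(Cn2cnc3c(Nc4ccccc4)nc(Cl)nc32)cc1` gives 2.05% in this assay.

Compound 3 stands lowest of the three numbers in this assay, though its nearest neighbour, compound 1, lies within the scatter of it; only compound 2 lies beyond the scatter above it. Within the data shown here, the single step available among the measured compounds, a number 5.1 percentage points lower from compound 1 to compound 3 (within the scatter), concerns hydrogen in place of chloro on an aromatic carbon and is within the scatter; it does not touch the change considered next.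

Compound 4 `Nc1ccccc1NC(=O)/C=C/c1ccc(Cn2cnc3c(NCc4ccccc4)nc(Cl)nc32)cc1` differs from compound 3 by benzyl in place of phenyl on a nitrogen on an aromatic ring. Among the measured compounds shown here, no measured pair shows this change on its own. Compound 2 carries the benzylamino group and gives 44.7%, but compound 2 differs from compound 3 elsewhere as well, so what share of that gap belongs to anilino to benzylamino cannot be read from these three compounds. The expectation for compound 4 is therefore a rise of a number 16 percentage points higher from compound 3 to compound 4 (beyond the scatter), with a wide range on either side. Compound 4 is estimated at 18%, between 2% and 42%.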

Compound 4, a percentage reported as inhibition, at one concentration (the size of the read-out at that concentration, not a potency): 4.62%
Beside the measured number, compound 4's estimate is 13.4 percentage points above it; the range from low to high includes it.
By their numbers in this assay, from the lowest: compounds 3, 4 and 1 (each within the scatter of the next); then compound 2.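

In this assay, benzyl in place of phenyl on a nitrogen on an aromatic ring gives a number 2.6 percentage points higher from compound 3 to compound 4 (within the scatter) and benzyl in place of 3-chlorophenyl at that same place gives a number 2.5 percentage points lower from compound 1 to compound 4 (within the scatter), so with the rest of the structure held constant, anilino to benzylamino does not by itself reproduce the number of compound 2. The gap goes instead with the other place: with the benzylamino group held constant, 2-((2-aminophenyl)carbamoyl)ethenyl in place of (2-aminophenyl)carbamoyl on an aromatic carbon comes with a number 40.1 percentage points lower from compound 2 to compound 4 (beyond the scatter) and is the only large single-place step among these compounds. Nothing measured here accounts for that step.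

The compounds shown leave open whether this large step would hold with anilino in place of benzylamino, and whether it would persist with a saturated ethylene chain in place of the ethenyl unit. They also leave open how a longer chain such as phenethyl, or a morpholine-bearing chain, would read on that nitrogen.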